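This account rests on a few compounds, and the source may have more. Where it says the series, first, only, none or still open, it means among the compounds named here.

Measured so far in a functional assay on MV4-11 cells (Homo sapiens) for antiproliferative activity, with a stated time of 6 days, tested at 6.25 uM; on this read-out higher numbers stand for a stronger effect at the one concentration tested and lower numbers for a weaker effect:
compound 1 `CNC(=O)N1CCCc2ccc(NC(=O)c3ccc(-c4cnn(S(C)(=O)=O)c4)cc3)cc21`, 40.2%
compound 2 `CNC(=O)N1CCCc2ccc(NC(=O)c3ccc(-c4ccn(C(C)=O)n4)cc3)cc21`, 91.4%

Compound 2 stands highest of the two numbers; its nearest neighbour is compound 1, separated by a number 51.2 percentage points higher from compound 1 to compound 2 (beyond the scatter). Compound 3 `CNC(=O)N1CCCc2ccc(NC(=O)c3ccc(-c4cn[nH]c4)cc3)cc21` differs from compound 2 as follows: 1H-pyrazol-4-yl in place of 1-acetyl-1H-pyrazol-3-yl on an aromatic carbon. Among the compounds with values here, the one measured step replaced one substituted pyrazole by another, whereas here the substituent is removed and the attachment point of the ring also shifts, so that step bears only loosely on the change. Within the data shown here, no direct precedent exists for an unsubstituted pyrazole in this assay. Compound 3 is therefore expected to fall between the two measured values, estimated at 60% (range 25% to 92%). The expected step is a number 31.4 percentage points lower from compound 2 to compound 3 (beyond the scatter), a drop beyond the scatter but uncertain in size.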

Compound 3, a percentage reported as inhibition, at one concentration (the size of the read-out at that concentration, not a potency): 98.3%
Compound 3: middle estimate off by 38.3 percentage points, on the low side, outside the stated range (above it).
By their numbers in this assay, from the lowest: compound 1; then compounds 2 and 3 (each within the scatter of the next).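

In this assay, hydrogen in place of methylsulfonyl on the aromatic nitrogen of the pyrazole gives a large gain (a number 58.1 percentage points higher from compound 1 to compound 3 (beyond the scatter)), so the weak number of compound 1 goes with methylsulfonyl and not with the 4-yl attachment. Replacing 1-acetyl-1H-pyrazol-3-yl with 1H-pyrazol-4-yl stays within the scatter (a number 6.9 percentage points higher from compound 2 to compound 3 (within the scatter)), so this position does not need a substituent on the ring nitrogen. Nothing at hand explains either step. As far as these compounds go, whether a methyl or a longer alkyl chain on that nitrogen behaves like acetyl or like methylsulfonyl remains open. Readings at one concentration also leave the potency of compound 2 and compound 3 unresolved.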